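Rearranging the ester chain on the sulfur of compound 2

A few compounds are considered here, and "the series" means these few. Any claim that something is new, unique, unknown or untested is made for them only; others in the source may bear on it.

The measured compounds:
Compound 1, `CCOC(=O)CCCSc1nc2cc(-n3nc(C(C)(C)C)sc3=O)c(Cl)cc2s1`: 17700 nM
Compound 2, `CCOC(=O)C(C)(C)Sc1nc2cc(-n3nc(C(C)(C)C)sc3=O)c(Br)cc2s1`: 43500 nM

In an assay on isolated protein for inhibition of protoporphyrinogen oxidase (Homo sapiens), read by capillary electrophoresis (a lower number here means a stronger inhibitor, a higher number a weaker inhibitor), compound 2 gives 43500 nM, the highest of the two numbers shown, while compound 1 gives 17700 nM, a difference that lies beyond the usual scatter. Compound 3, `CCOC(=O)CCCSc1nc2cc(-n3nc(C(C)(C)C)sc3=O)c(Br)cc2s1`, has not yet been measured. It keeps all the atoms of compound 2 but joins them differently: 3-(ethoxycarbonyl)propyl in place of 1-(ethoxycarbonyl)-1-methylethyl on a sulfur. For the measured compounds named here, no measured pair shows this change on its own, so its size is not known from the data. Compound 1 carries the same 3-(ethoxycarbonyl)propyl chain and gives the lower of the two numbers, which suggests that the step from compound 2 to compound 3 is expected to run toward a lower number, of moderate size, a 2.2-fold lower number from compound 2 to compound 3 (0.34 log units; beyond the scatter). Compound 3 is therefore estimated at 20000 nM in this assay, with a range from 8000 nM to 50000 nM.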

Compound 3, inhibition constant: 245000 nM
The estimate for compound 3 lay 12-fold (1.09 log units) below the measured number; measured number above the stated range.
By their numbers in this assay, from the lowest: compound 1; then compound 2; then compound 3.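

In this assay, rearranging the same atoms on the sulfur, with 3-(ethoxycarbonyl)propyl in place of 1-(ethoxycarbonyl)-1-methylethyl, gives a 5.6-fold higher number from compound 2 to compound 3 (0.75 log units; beyond the scatter), so the way this chain is joined matters even though its atoms and its counted features stay the same. With 3-(ethoxycarbonyl)propyl held fixed, bromo in place of chloro on an aromatic carbon gives a 14-fold higher number from compound 1 to compound 3 (1.14 log units; beyond the scatter), which shows that the halogen also shifts the number and that the earlier gap between compound 1 and compound 2 combined two changes, not the chain alone. No supporting data here bear on why either change has this effect.

For the compounds shown here, with only these compounds, the chain change has been seen only with bromo on the core, so whether it would run the same way and reach a similar size with chloro remains open. Also open, as far as these compounds go, is how a carboxylic acid in place of the ethyl ester, or a longer chain on the sulfur, would read in this assay.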